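Benzyl on the Amine Nitrogen of Compound 3

The source may hold more compounds than are shown below. What is called first, only, known or untested is meant among the compounds shown, and "the series" means these compounds.

Three compounds share one core. Compound 1 `COc1cccc2c1OCC(C)(C)C2N` gives 4.3% in an assay on BTI cells for inhibition of Amine oxidase [flavin-containing] B (Homo sapiens), read by fluorescence, with a stated time of 20 min, tested at 1 uM; on this read-out lower numbers stand for less inhibition and higher numbers for more inhibition at the one concentration tested (going by the name of the read-out). Compound 2 `C#CCNC1c2ccccc2OCC1(C)C` gives 11.6% in this assay, and compound 3 `C#CCNC1c2cccc(OC)c2OCC1(C)C` gives 13.8% in this assay. Compound 3 carries the numerically highest of the three readings, yet the gaps to the other two, a number 9.5 percentage points higher from compound 1 to compound 3 (within the scatter) and a number 2.2 percentage points higher from compound 2 to compound 3 (within the scatter), both fall within the scatter, so the three compounds are not separated by these numbers.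

Compound 4 `C#CCN(Cc1ccccc1)C1c2cccc(OC)c2OCC1(C)C` has not yet been measured. It differs from compound 3 in one place: benzyl in place of hydrogen on an amine nitrogen. Going by the values given here, the one measured step that touches the same amine nitrogen is a number 9.5 percentage points higher from compound 1 to compound 3 (within the scatter), a change that stayed within the scatter; the other step, a number 2.2 percentage points higher from compound 2 to compound 3 (within the scatter), sits on an aromatic carbon and was likewise within the scatter. Among the compounds with values here, no measured compound carries a benzyl, so the step to compound 4 has no direct precedent. On this basis the expected change in this assay is small, with no direction beyond the scatter: the estimated step is a number 1.8 percentage points lower from compound 3 to compound 4 (within the scatter). Compound 4 is therefore expected to give about 12%, within a range from 0% to 28%.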

Compound 4, a percentage reported as inhibition, at one concentration (the size of the read-out at that concentration, not a potency): 14.7%
The estimate for compound 4 lay 2.7 percentage points below the measured number, within the range that was stated.
By their numbers in this assay, from the lowest: compounds 1, 2, 3 and 4 (each within the scatter of the next, the first and the last beyond it).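

The amine nitrogen of compound 3 accepts a benzyl in place of its hydrogen, and in this assay the result is a number 0.9 percentage points higher from compound 3 to compound 4 (within the scatter). Until now this nitrogen had carried only hydrogen or propargyl; compound 4 shows that a group with one six-membered aromatic ring of carbon only can sit there alongside the propargyl, leaving the nitrogen with no hydrogen, without a step that rises above the scatter in either direction. The compounds offer no measured finding that could explain this outcome, and a single step on one core supports no general rule for this nitrogen.

On these data alone, whether a methyl, a longer chain such as phenylethyl, or a benzyl with a fluorine on its ring would read the same at this nitrogen remains open, as does whether benzyl would give a comparable step on compound 2, which has hydrogen in place of the methoxy. Also open, as far as these compounds go, is what a benzyl would do on this nitrogen with the propargyl replaced by hydrogen.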